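Exchange of the acyl aryl group in a thiazole hydrazone series

A few compounds are considered here, and "the series" means these few. Any claim that something is new, unique, unknown or untested is made for them only; others in the source may bear on it.

Compound 1 `CN(C(=O)NC(=O)c1ccc(Cl)cc1Cl)c1nc(C(F)(F)F)c(C(=O)N/N=C/c2cccc(C(F)(F)F)c2)s1`: 11.2 ug/mL
Compound 2 `CN(C(=O)NC(=O)c1ccc(Cl)cc1Cl)c1nc(C(F)(F)F)c(C(=O)N/N=C/c2ccc(C(F)(F)F)cc2)s1`: 12.4 ug/mL

Within the data shown here, in a functional assay on HepG2 cells (Homo sapiens) for inhibition, read by MTT assay, with a stated time of 72 h (a lower number here means a stronger inhibitor, a higher number a weaker inhibitor), compound 2 gives the higher of the two numbers, yet the only measured step, a 1.1-fold higher number from compound 1 to compound 2 (0.04 log units; within the scatter), lies within the scatter, so compound 1 and compound 2 are not distinguished. Compound 3 `CN(C(=O)NC(=O)c1ccccc1F)c1nc(C(F)(F)F)c(C(=O)N/N=C/c2ccc(C(F)(F)F)cc2)s1` differs from compound 2 by 2-fluorophenyl in place of 2,4-dichlorophenyl on a carbonyl carbon. No measured step touches this carbonyl-linked ring, so no shown step bears on the change. With nothing to point either way, the expected step is a 1.1-fold higher number from compound 2 to compound 3 (0.05 log units; within the scatter). Compound 3 is therefore estimated at 14 ug/mL, with a range from 5 ug/mL to 40 ug/mL that is expected to be wide.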

Compound 3, half-maximal inhibitory concentration: 4.56 ug/mL
Compound 3: middle estimate off by 3.1-fold (0.49 log units), on the high side; the measured number lies below the stated range.
By their numbers in this assay, from the lowest: compound 3; then compounds 1 and 2 (each within the scatter of the next).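

In this assay, the ring on the carbonyl carbon proves able to shift the number: 2-fluorophenyl in place of 2,4-dichlorophenyl gives a 2.7-fold lower number from compound 2 to compound 3 (0.43 log units; beyond the scatter), while the earlier exchange of trifluoromethylphenyl groups gave only a 1.1-fold higher number from compound 1 to compound 2 (0.04 log units; within the scatter). Nothing shown accounts for this step.

Since the fluorine and the two chlorines change together, the compounds shown do not separate their contributions, and an unsubstituted phenyl or a methoxyphenyl on that carbonyl carbon would be needed to do so. On these data alone, whether the step also holds with 3-(trifluoromethyl)phenyl in the other place remains open.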